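The source may hold more compounds than are shown below. What is called first, only, known or untested is meant among the compounds shown, and "the series" means these compounds.

Measured so far:
compound 1 `O=C1OCC[C@@H]1NC(=S)SCCOc1ccccc1Cc1ccccc1` gives 39500 nM in a functional assay on MCF7 cells (Homo sapiens) for antiproliferative activity, read by MTT assay, with a stated time of 72 h; a lower number here means a stronger inhibitor, a higher number a weaker inhibitor
compound 2 `O=C1OCC[C@@H]1NC(=S)SCCOc1ccccc1[N+](=O)[O-]` gives > 64000 nM in this assay

Compound 2 stands at a limit of this assay, (the limit of > 64000 nM in this assay, at which 1 of the 2 values shown sits), so no number is known for it. Compound 3 `CCOc1ccccc1OCCSC(=S)N[C@H]1CCOC1=O` differs from compound 2 by ethoxy in place of nitro on an aromatic carbon, ethoxy in place of nitro. For the measured compounds named here, the only measured step, an at least 1.6-fold higher number from compound 1 to compound 2 (0.20 log units; that floor lies within the scatter), swaps benzyl for nitro and its floor lies within the scatter, so it says little about an ethoxy group. Going by the values given here, no step exchanges nitro for ethoxy. Compound 3 is expected to sit near the weak end of the series, with an estimated 45000 nM (range 12000 nM to 150000 nM), an expected step of an at least 1.4-fold lower number from compound 2 to compound 3 (0.15 log units; that floor lies within the scatter).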

Compound 3, half-maximal inhibitory concentration: > 64000 nM
Compound 3: only a limit was reported; the forecaster's own chance of this, stated with the estimate: 45%; middle value at least 1.4-fold (0.15 log units) from the limit.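

In this assay compound 3 gives > 64000 nM, which is a limit and not a number. Ethoxy in place of benzyl on this aromatic carbon gives an at least 1.6-fold higher number from compound 1 to compound 3 (0.20 log units; that floor lies within the scatter), so a second replacement of benzyl again yields only a floor inside the scatter. The step between the two limits cannot be read, which leaves nitro and ethoxy unranked, and the series now gathers at one limit: the limit of > 64000 nM in this assay, at which 2 of the 3 values shown sit.

Open, from the compounds shown here alone, is whether a group other than benzyl, such as an amine or a longer ether chain, gives a readable number at this place. Also open, going by these compounds, is whether benzyl truly differs from nitro or ethoxy beyond the scatter.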